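A few compounds are considered here, and "the series" means these few. Any claim that something is new, unique, unknown or untested is made for them only; others in the source may bear on it.

In an assay on HEK293 cells for agonist activity at Toll-like receptor 2 (Homo sapiens) (on this read-out lower numbers stand for an effect already at smaller amounts and higher numbers for an effect only at larger amounts of compound), compound 1 `CCCCCCCCCCCC(=O)OC[C@H](CSC[C@@H](N)C(=O)NCCCS(=O)(=O)O)OC(=O)CCCCCCCCCCC` gives 5560 nM, compound 2 `CCCCCCCCCCCC(=O)OC[C@H](CSC[C@@H](N)C(=O)NC(C)CCC(C)C)OC(=O)CCCCCCCCCCC` gives 190 nM, and compound 3 `CCCCCCCCCCCC(=O)OC[C@H](CSC[C@@H](N)C(=O)NC(CC)COC)OC(=O)CCCCCCCCCCC` gives 71.8 nM.

Compound 1 thus stands at the highest number of the three, with every other compound well beyond the scatter below it. Compound 4 `CCCCCCCCCCCC(=O)OC[C@H](CSC[C@@H](N)C(=O)NCCCCCCCCCC(=O)O)OC(=O)CCCCCCCCCCC` changes compound 1 at one spot: 6-carboxyhexyl in place of sulfo on a saturated chain carbon, three bonds along the chain from an amide-type nitrogen. Two measured steps start from the same spot of compound 1. Both a 29-fold lower number from compound 1 to compound 2 (1.47 log units; beyond the scatter) and a 77-fold lower number from compound 1 to compound 3 (1.89 log units; beyond the scatter) are large, yet in each the group that enters carries no hydrogen-bond donor, whereas 6-carboxyhexyl keeps one donor and one acceptor. The step of a 3.7-fold lower number from compound 1 to compound 4 (0.57 log units; beyond the scatter) is therefore expected to be downward but smaller than either of those. Compound 4 is estimated at 1500 nM, within 400 nM to 6000 nM.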

Compound 4, half-maximal effective concentration: 4400 nM
Compound 4: the middle estimate sits 2.9-fold (0.47 log units) below what was measured, within the range that was stated.
By their numbers in this assay, from the lowest: compound 3; then compound 2; then compounds 4 and 1 (each within the scatter of the next).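

Swapping sulfo for 6-carboxyhexyl at this chain position hardly matters in this assay, with a 1.3-fold lower number from compound 1 to compound 4 (0.10 log units; within the scatter) as the whole change, so lengthening the chain while keeping an acid at its end does not by itself give the low numbers. The branched groups remain far ahead, with a 61-fold higher number from compound 3 to compound 4 (1.79 log units; beyond the scatter) and a 23-fold higher number from compound 2 to compound 4 (1.36 log units; beyond the scatter) as the steps. Nothing measured here gives a reason for this.

Still open, going by these compounds, is whether those low numbers need the branching or only the loss of the acid end. An unbranched alkyl chain with no acid, or one ending in an amine, would separate the two.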